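Methyl for methoxy on the benzyl ring of the series

The source may report more compounds than this note shows. Statements on the series, on what has been measured and on what is new or still open speak of the compounds shown alone.

Measured compounds in an ADME assay on HEK-293T cells (Homo sapiens) for inhibition, read by CCK-8 assay, with a stated time of 48 h, tested at 20 uM; on this read-out higher numbers stand for more inhibition of growth at the one concentration tested and lower numbers for less inhibition of growth: compound 1 `COc1ccc(Cc2nnc(NC(=O)/C(C#N)=C/c3ccccc3OS(=O)(=O)c3ccc(OC)cc3)s2)cc1` gives 30%; compound 2 `COc1ccc(Cc2nnc(NC(=O)/C(C#N)=C/c3ccccc3OS(=O)(=O)c3ccccc3[N+](=O)[O-])s2)cc1` gives 18%; compound 3 `COc1ccc(Cc2nnc(NC(=O)/C(C#N)=C/c3ccccc3OS(=O)(=O)c3ccc(F)cc3)s2)cc1` gives 6%.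

Compound 3 stands lowest of the three: a number 24 percentage points lower from compound 1 to compound 3 (beyond the scatter) and a number 12 percentage points lower from compound 2 to compound 3 (beyond the scatter). Compound 4 `Cc1ccc(Cc2nnc(NC(=O)/C(C#N)=C/c3ccccc3OS(=O)(=O)c3ccc(F)cc3)s2)cc1` is made from compound 3 by the change (methyl in place of methoxy on an aromatic carbon). Among the measured compounds shown here, no measured step touches this benzyl ring; the measured steps all swap the aryl on the sulfonyl sulfur. The nearest relative is a number 24 percentage points lower from compound 1 to compound 3 (beyond the scatter), a loss of methoxy at the other ring, and a number 12 percentage points lower from compound 1 to compound 2 (beyond the scatter) is also a loss of methoxy there. Both point down, but compound 3 already sits near the floor, so only a small change is expected for compound 4, a number 1 percentage points lower from compound 3 to compound 4 (within the scatter), giving an estimate of 5% (range 0% to 18%).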

Compound 4, percent growth inhibition at one concentration: 11%
Estimate against measurement, compound 4: 6 percentage points below; the range from low to high includes it.
By their numbers in this assay, from the lowest: compounds 3, 4 and 2 (each within the scatter of the next, the first and the last beyond it); then compound 1.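

In this assay, among the compounds shown here, the change from 4-methoxybenzyl to 4-methylbenzyl gives the only step on this ring, a number 5 percentage points higher from compound 3 to compound 4 (within the scatter) and so, with 4-fluorophenyl on the sulfonyl sulfur, the two groups cannot be told apart at this position. The methoxy oxygen is therefore not needed to keep the number at this low level. Nothing at hand bears on a cause.

On these data alone, whether the same holds with 4-methoxyphenyl on the sulfonyl sulfur, as in compound 1, stays open. Also open, as far as these compounds go, is whether an amine or a carboxylic acid at this position would move the number beyond the scatter.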